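This account rests on a few compounds, and the source may have more. Where it says the series, first, only, none or still open, it means among the compounds named here.

Measured compounds:
compound 1 `Cc1nn(-c2ncnc3nc[nH]c23)c2c1C(OC1CCCC1)CC(=O)N2`, 62 nM
compound 2 `Cc1nn(-c2ncnc3nc[nH]c23)c2c1C(OCc1ccccc1F)CC(=O)N2`, 78 nM
compound 3 `Cc1cc(C)n(CCOC2CC(=O)Nc3c2c(C)nn3-c2ncnc3nc[nH]c23)n1`, 2000 nM

All three share one core and differ only in the group carried on an oxygen on a saturated carbon. In a functional assay on HEK293 cells for agonist activity at G-protein coupled receptor 39 (Homo sapiens), read by scintillation proximity assay and inositol phosphate accumulation, with a stated time of 75 min (on this read-out higher numbers stand for an effect only at larger amounts of compound and lower numbers for an effect already at smaller amounts), compound 1 sits at one end of the range: its nearest neighbour is compound 2, with a 1.3-fold higher number from compound 1 to compound 2 (0.10 log units; within the scatter), so the two lie within the scatter of each other; its furthest is compound 3, with a 32-fold higher number from compound 1 to compound 3 (1.51 log units; beyond the scatter). Compound 2 and compound 3 are separated by a 26-fold higher number from compound 2 to compound 3 (1.41 log units; beyond the scatter).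

Compound 4 `CCCCCCCCOC1CC(=O)Nc2c1c(C)nn2-c1ncnc2nc[nH]c12` has not been measured. It differs from compound 1 by octyl in place of cyclopentyl on an oxygen on a saturated carbon. The step from compound 1 to compound 2, exchanging one carbon-only group for another carbon-only group, stayed within the scatter, while the large loss in the step from compound 1 to compound 3 came with a chain carrying a heteroaromatic ring, which octyl does not have. Octyl is longer than cyclopentyl and has no ring, so the bearing is indirect, and a change within or slightly beyond the scatter is expected in this assay. Compound 4 is therefore estimated at 100 nM, with a range from 30 nM to 400 nM. The expected step is a 1.6-fold higher number from compound 1 to compound 4 (0.21 log units; within the scatter).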

Compound 4, half-maximal effective concentration: 388 nM
The estimate for compound 4 lay 3.9-fold (0.59 log units) below the measured number, within the range that was stated.
By their numbers in this assay, from the lowest: compounds 1 and 2 (each within the scatter of the next); then compound 4; then compound 3.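

In this assay, the position proves sensitive to a group made only of carbon: octyl in place of cyclopentyl gives a 6.3-fold higher number from compound 1 to compound 4 (0.80 log units; beyond the scatter), so a loss here does not require a heteroaromatic ring on the chain, as compound 3 alone might have suggested. The open chain also falls short of the fluorinated ring group, with a 5.0-fold higher number from compound 2 to compound 4 (0.70 log units; beyond the scatter), yet it still does better than the pyrazole-bearing chain, with a 5.2-fold lower number from compound 3 to compound 4 (0.71 log units; beyond the scatter), so the groups on this oxygen now spread over graded steps rather than splitting into two levels. No measurement shown gives a reason for these steps.

Compound 4 lengthens the group and removes its ring in one change, so it remains open which of the two accounts for the step, and a shorter chain such as butyl or a ring held on a chain such as cyclopentylmethyl would tell them apart. Also open, going by these compounds, is how an amine or a carboxylic acid at the end of a chain on this oxygen would fare.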